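Anilide swap on a hydroxyamino pyranone: expected cytotoxicity

The compounds below may be only part of what the source reports. "The series", "measured", "known", "first", "only" and "open" are said of these compounds alone.

Measured compounds:
compound 1, `Cc1ccc(-c2cc(NO)c(C(=O)Nc3ccccc3)c(=O)o2)cc1`, > 20000 nM
compound 2, `O=C(Nc1ccc(Cl)cc1)c1c(NO)cc(-c2ccccc2)oc1=O`, > 20000 nM

Of the compounds shown here, two sharing one core have been tested in an ADME assay on Huh-7 cells (Homo sapiens) for cytotoxicity, read by a luciferase reporter and WST assay, with a stated time of 3 days; on this read-out higher numbers stand for lower toxicity in this test and lower numbers for higher toxicity in this test. Compound 1, `Cc1ccc(-c2cc(NO)c(C(=O)Nc3ccccc3)c(=O)o2)cc1`, gives > 20000 nM in this assay, which is a limit of the test and not a number. Compound 2, `O=C(Nc1ccc(Cl)cc1)c1c(NO)cc(-c2ccccc2)oc1=O`, likewise gives > 20000 nM, again a limit rather than a measured value. Compound 2 therefore stands at the ceiling of what this test reports, as does the only other compound shown: the limit of > 20000 nM in this assay, at which 2 of the 2 values shown sit.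

Compound 3, `Cc1cccc(NC(=O)c2c(NO)cc(-c3ccccc3)oc2=O)c1`, has not yet been measured. It differs from compound 2 in one place: 3-methylphenyl in place of 4-chlorophenyl on an amide-type nitrogen. For the measured compounds named here, no step between two measured compounds is known here, so the size of this change can only be expected, not read off.

Since both measured compounds sit at the limit, compound 3 is expected to show no step beyond the scatter: a step that the limit leaves unreadable from compound 2 to compound 3. Compound 3 is estimated to give 25000 nM in this assay, within 12000 nM to 60000 nM, most likely again reported only as a limit.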

Compound 3, half-maximal cytotoxic concentration: > 20000 nM
Compound 3 gave a limit, no number (the forecaster's own chance of this, stated with the estimate: 80%); the middle value does not contradict the limit.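

In this assay compound 2 and compound 3 both give only a limit, so no step can be read for 3-methylphenyl in place of 4-chlorophenyl on the amide-type nitrogen. The compounds shown leave open whether their cytotoxicity differs at all, since every value stands at one ceiling: the limit of > 20000 nM in this assay, at which 3 of the 3 values shown sit.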